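A Chlorophenyl Variant of Compound 1

The source may hold more compounds than are shown below. What is called first, only, known or untested is meant among the compounds shown, and "the series" means these compounds.

Compound 1 `Cc1ccc(NC(=O)Nc2cccc(CNc3nccnc3Cl)c2)c(C)c1` gives 10100 nM in a functional assay on MGC-803 cells (Homo sapiens) for antiproliferative activity, read by MTT assay, with a stated time of 48 h (on this read-out higher numbers stand for weaker inhibition and lower numbers for stronger inhibition), the higher of the two numbers recorded. Compound 2 `CC(C)(C)c1ccc(NC(=O)Nc2cccc(CNc3nccnc3Cl)c2)cc1` gives 4820 nM in this assay, a lower number whose gap from compound 1 lies beyond the scatter. Compound 3 `O=C(Nc1cccc(CNc2nccnc2Cl)c1)Nc1ccccc1Cl` has not yet been measured. 2-chlorophenyl in place of 2,4-dimethylphenyl on an amide-type nitrogen The measured pair offers no guide to a 2-chlorophenyl on the amide-type nitrogen. The step of a 1.3-fold lower number from compound 1 to compound 3 (0.10 log units; within the scatter) is therefore expected to be small, not beyond the scatter. Compound 3 is estimated at 8000 nM in this assay, with a range from 3000 nM to 20000 nM.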

Compound 3, half-maximal inhibitory concentration: 7130 nM
For compound 3 the middle estimate is 1.1-fold (0.05 log units) above the measured one; measured number inside the range.
By their numbers in this assay, from the lowest: compounds 2, 3 and 1 (each within the scatter of the next, the first and the last beyond it).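

In this assay, among the compounds shown here, putting 2-chlorophenyl in place of 2,4-dimethylphenyl on the amide-type nitrogen gives a 1.4-fold lower number from compound 1 to compound 3 (0.15 log units; within the scatter), the first comparison that differs in one place. At this position, then, the two aryl groups cannot be told apart on this read-out, although one carries chlorine and the other carries two methyl groups. Nothing measured here offers an explanation for this result.

From the compounds shown here alone, whether a phenyl bearing an amine or a carboxylic acid would shift the number beyond the scatter remains open. So does the contribution of the rest of the shared core.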